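The compounds below may be only part of what the source reports. "The series", "measured", "known", "first", "only" and "open" are said of these compounds alone.

Measured compounds in a functional assay on ECa-109 cells for inhibition, with ECa-109 cell line (Homo sapiens) as the target, read by sulforhodamine B assay; a higher number here means a weaker inhibitor, a lower number a stronger inhibitor:
Compound 1 `O=C1C=C(NCc2ccccc2)C(=O)c2c1nc1n2[C@H]2OC[C@@H](O)[C@H]2OC1` gives > 8000 nM, a limit of the assay.
Compound 2 `CCOc1ccccc1NC1=CC(=O)c2c(nc3n2[C@H]2OC[C@@H](O)[C@H]2OC3)C1=O` gives 4320 nM.
Compound 3 `O=C1C(NCc2ccccc2)=CC(=O)c2c1nc1n2[C@H]2OC[C@@H](O)[C@H]2OC1` gives > 8000 nM, a limit of the assay.

Compound 1 thus stands at a limit rather than a number, and the limit of > 8000 nM in this assay, at which 2 of the 3 values shown sit, is the level at which two of the three values sit. Among the compounds with values here, compound 2 is the only member with a numerical value. Within the data shown here, the single measured step, an at least 1.8-fold higher number from compound 2 to compound 3 (0.26 log units; that floor lies within the scatter), runs from that number to a limit, so it gives no size for any change of the amine substituent that could be carried over.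

Compound 4 `O=C1C=C(N2CCC2)C(=O)c2c1nc1n2[C@H]2OC[C@@H](O)[C@H]2OC1` is not yet measured. It differs from compound 1 by azetidin-1-yl in place of benzylamino on a double-bonded ring carbon. Among the measured compounds shown here, no measured step covers this exchange: the benzylamino group that leaves is present in compound 1 and compound 3, while compound 2 carries a different group. With compound 1 itself at a limit, no step beyond the scatter can be read off in either direction, and the expectation for compound 4 is that it remains weak. Compound 4 is estimated at 9000 nM, within 3000 nM to 30000 nM. For compound 4 this corresponds to an expected step that the limit leaves unreadable from compound 1 to compound 4.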

Compound 4, half-maximal inhibitory concentration: > 16000 nM
Compound 4 gave a limit, no number (the forecaster's own chance of this, stated with the estimate: 60%); at least 1.7-fold (0.24 log units) between middle value and limit.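

Compound 1 and compound 4 both stand at limits of the assay rather than at numbers, so the exchange of benzylamino for azetidin-1-yl gives no readable step. The compounds shown leave open where the true values of compound 1 and compound 4 lie, and whether this exchange changes inhibition of the cells at all.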